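The source may hold more compounds than are shown below. What is called first, only, known or untested is meant among the compounds shown, and "the series" means these compounds.

Series notes. The shared core is carried by compound 1 `CC1(C)[C@H]2CC[C@]1(C)N(Cc1cn(-c3ccccc3Cl)nn1)C(=O)C2` and compound 2 `CC1(C)[C@H]2CC[C@]1(C)N(Cc1cn(-c3cccc(Cl)c3)nn1)C(=O)C2`. In a functional assay on LoVo cells (Homo sapiens) for inhibition, read by MTT assay, with a stated time of 24 h (a higher number here means a weaker inhibitor, a lower number a stronger inhibitor), compound 1 gives 190 nM, and compound 2 gives 70 nM. For the measured compounds named here, compound 2 holds the lowest of the two numbers so far; its nearest neighbour is compound 1, and the step of a 2.7-fold lower number from compound 1 to compound 2 (0.43 log units; beyond the scatter) sets the two apart beyond the scatter.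

Compound 3 `CC1(C)[C@H]2CC[C@]1(C)N(Cc1cn(-c3cccc(Br)c3)nn1)C(=O)C2` is not yet measured. It differs from compound 2 by bromo in place of chloro on an aromatic carbon. Going by the values given here, the one measured step, a 2.7-fold lower number from compound 1 to compound 2 (0.43 log units; beyond the scatter), puts 3-chlorophenyl in place of 2-chlorophenyl on an aromatic nitrogen; no measured step exchanges chloro for bromo, so nothing among the two numbers bears directly on the change from compound 2 to compound 3. Among the compounds with values here, with no step of this kind to draw on, the expected movement in this assay is a 1.2-fold lower number from compound 2 to compound 3 (0.07 log units; within the scatter), which is not beyond the scatter in either direction. Compound 3 is therefore estimated at 60 nM, with a range of 25 nM to 150 nM.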

Compound 3, half-maximal inhibitory concentration: 30 nM
Compound 3: the middle estimate sits 2.0-fold (0.30 log units) above what was measured; the measured number falls inside the stated range.
By their numbers in this assay, from the lowest: compound 3; then compound 2; then compound 1.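

In this assay, for the compounds shown here, the earlier pair showed only that moving the chlorine changes the number; here, with the place on the ring held constant, the identity of the halogen also matters, as bromo in place of chloro gives a 2.3-fold lower number from compound 2 to compound 3 (0.37 log units; beyond the scatter). Taken together with the earlier change of position, the full replacement of 2-chlorophenyl by 3-bromophenyl gives a 6.3-fold lower number from compound 1 to compound 3 (0.80 log units; beyond the scatter), and compound 3 now has the lowest number of the three, with its steps to both others beyond the scatter. No supporting evidence is available on the origin of the chloro-to-bromo step, so it stands as an observation from a single pair.

The compounds shown leave open whether iodo, methyl, methoxy or an amine on that same aromatic carbon would lower the number further or raise it, so the chloro-to-bromo step cannot yet be placed in any wider trend. They also leave open whether the same exchange would move the number in the same direction on the 2-chlorophenyl of compound 1.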